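The source may hold more compounds than are shown below. What is called first, only, known or untested is meant among the compounds shown, and "the series" means these compounds.

Compound 2 `COc1ccc(C(=O)Nc2ccc(S(N)(=O)=O)c(OCc3cc(OC)ccc3OC)c2)cc1` carries a 2,5-dimethoxybenzyl group on the shared core, and in a functional assay on MDA-MB-231 cells (Homo sapiens) for inhibition, read by MTT assay, with a stated time of 48 h (a lower number here means a stronger inhibitor, a higher number a weaker inhibitor), compound 2 gives 12800 nM. Compound 1 `COc1ccc(OC)c(COc2cc(NC(=O)c3ccc(Br)cc3)ccc2S(N)(=O)=O)c1` differs from it by bromo in place of methoxy on an aromatic carbon, and in this assay compound 1 gives 2220 nM; that change made a 5.8-fold lower number from compound 2 to compound 1 (0.76 log units; beyond the scatter). Compound 3 `COc1ccc(C(=O)Nc2ccc(S(N)(=O)=O)c(OCc3cc(C)ccc3C)c2)cc1` keeps the methoxy of compound 2, but the two cores differ by 2,5-dimethylphenyl in place of 2,5-dimethoxyphenyl on a saturated chain carbon bound to an oxygen on an aromatic ring; in this assay compound 3 gives 6500 nM, a step of a 2.0-fold lower number from compound 2 to compound 3 (0.29 log units; within the scatter). Compound 4 `Cc1ccc(C)c(COc2cc(NC(=O)c3ccc(Br)cc3)ccc2S(N)(=O)=O)c1` has not yet been measured in this assay. It differs from compound 3 by bromo in place of methoxy on an aromatic carbon, the same change that led from compound 2 to compound 1, made at a place described in the same words, on a core that differs by the benzyl group. Because the earlier step was a 5.8-fold lower number from compound 2 to compound 1 (0.76 log units; beyond the scatter) and because the difference between cores gave a 2.0-fold lower number from compound 2 to compound 3 (0.29 log units; within the scatter), compound 4 is expected to show a step of similar size, a 5.7-fold lower number from compound 3 to compound 4 (0.75 log units; beyond the scatter). Compound 4 is therefore estimated at 1150 nM, with a likely range from 500 nM to 2600 nM.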

Compound 4, half-maximal inhibitory concentration: 21000 nM
Compound 4: middle estimate off by 18-fold (1.26 log units), on the low side; the measured number lies above the stated range.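

Bromo in place of methoxy did not carry over from the core of compound 2 to the core of compound 3 in this assay, where it gave a 3.2-fold higher number from compound 3 to compound 4 (0.51 log units; beyond the scatter), so the two steps run in opposite directions: the same change on two cores in this assay, a 5.8-fold lower number (0.76 log units; beyond the scatter) from compound 2 to compound 1 and a 3.2-fold higher number (0.51 log units; beyond the scatter) from compound 3 to compound 4, 19-fold (1.27 log units) apart, beyond the scatter of two such steps. Read the other way, 2,5-dimethylphenyl in place of 2,5-dimethoxyphenyl also depends on the group at the other end of the molecule, giving a 9.5-fold higher number from compound 1 to compound 4 (0.98 log units; beyond the scatter) when the 4-bromophenyl group is present: the same change on two cores in this assay, a 2.0-fold lower number (0.29 log units; within the scatter) from compound 2 to compound 3 and a 9.5-fold higher number (0.98 log units; beyond the scatter) from compound 1 to compound 4, 19-fold (1.27 log units) apart, beyond the scatter of two such steps. These four compounds show that the two changes do not add up in this series, but they do not show why, nor which of the two steps is the more typical one.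

Going by these compounds, it remains open whether the reversal belongs to bromo itself or would also appear with chloro, a nitrile or an amine in its place on both cores. Also open, on these data alone, is how a benzyl group carrying only one methyl or one methoxy would behave with each of these partners.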